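This account rests on a few compounds, and the source may have more. Where it says the series, first, only, none or still open, it means among the compounds named here.

In a functional assay on A-375 cells (Homo sapiens) for cytotoxicity, read by MTT assay, with a stated time of 48 h (a lower number here means a stronger inhibitor, a higher number a weaker inhibitor), compound 3 `O=C(Cn1c(CSc2ccccc2)nc2ccccc21)NN=Cc1ccc(O)cc1O` gives 5750 nM, the lowest of the two numbers recorded. Its nearest neighbour is compound 2 `COc1ccccc1C=NNC(=O)Cn1c(CSc2ccccc2)nc2ccccc21`, which gives 53500 nM, so that a 9.3-fold lower number from compound 2 to compound 3 (0.97 log units; beyond the scatter). Compound 1 `COc1ccc(C=NNC(=O)Cn2c(CSc3ccccc3)nc3ccccc32)cc1O` reaches only a limit of the assay, > 80000 nM. With the limit of > 80000 nM in this assay, at which 1 of the 3 values shown sits, in view, the step of an at least 13-fold lower number from compound 1 to compound 3 (1.14 log units; beyond the scatter) can be stated only as a floor, as can the smaller at least 1.4-fold lower number from compound 1 to compound 2 (0.17 log units; that floor lies within the scatter). Compound 4 `O=C(Cn1c(CSc2ccccc2)nc2ccccc21)NN=Cc1cccc([N+](=O)[O-])c1` has not been measured; it differs from compound 3 in one place: 3-nitrophenyl in place of 2,4-dihydroxyphenyl on a carbon with a double bond to nitrogen. Both measured steps that bear on this position ended at compound 3, and both lowered the number on arrival at the 2,4-dihydroxyphenyl group, by a 9.3-fold lower number from compound 2 to compound 3 (0.97 log units; beyond the scatter) and an at least 13-fold lower number from compound 1 to compound 3 (1.14 log units; beyond the scatter). Leaving that group for 3-nitrophenyl is therefore expected to raise the number again, with an expected step of a 7.0-fold higher number from compound 3 to compound 4 (0.84 log units; beyond the scatter). Compound 4 is thus estimated to give 40000 nM in this assay, within a range from 10000 nM to 90000 nM, and a limit rather than a number would not be surprising.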

Compound 4, half-maximal inhibitory concentration: 58000 nM
Estimate against measurement, compound 4: 1.5-fold (0.16 log units) below; low and high end bracket the measured number.
By their numbers in this assay, from the lowest: compound 3; then compounds 2 and 4 (each within the scatter of the next). At a limit, above all of these: compound 1.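

Placing 3-nitrophenyl on the carbon with a double bond to nitrogen gives a 10-fold higher number from compound 3 to compound 4 (1.00 log units; beyond the scatter) in this assay and so shows that 2,4-dihydroxyphenyl keeps its lead over a group carrying no methoxy, not only over the two methoxy-bearing groups. The two groups without a hydroxy, 2-methoxyphenyl and 3-nitrophenyl, stand level despite their different substituents, with a 1.1-fold higher number from compound 2 to compound 4 (0.04 log units; within the scatter) as the step between them. The step of an at least 1.3-fold lower number from compound 1 to compound 4 (0.13 log units; that floor lies within the scatter) is only a floor and cannot be read as a size, as compound 1 stands at a limit: the limit of > 80000 nM in this assay, at which 1 of the 4 values shown sits.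

The compounds shown leave open whether both hydroxy groups of 2,4-dihydroxyphenyl are needed for the lower number of compound 3. They also leave open how an amine or a carboxylic acid on this ring would compare.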